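The compounds below may be only part of what the source reports. "The series", "measured", "known", "first", "only" and "open" are said of these compounds alone.

The set is a small one, held together by a shared core that carries a chloromethyl-substituted benzyl group, and it is followed in a functional assay on UO-31 cells (Homo sapiens) for cytotoxicity, read by sulforhodamine B assay, with a stated time of 48 h; a lower number here means that less compound is tolerated, a higher number that more compound is tolerated. Compound 1, `ClCc1cccc(Cn2cnc3c(Cl)nc(Cl)nc32)c1`, gives 5880 nM in this assay. Among the measured compounds shown here, compound 2, `ClCc1cccc(Cn2cnc3nc(Cl)nc(Cl)c32)c1`, gives 72400 nM in this assay; of these two numbers the higher one belongs to compound 2, and the two compounds differ in more than one place, so no single step connects them. Compound 3, `ClCc1ccccc1Cn1cnc2nc(Cl)nc(Cl)c21`, was also taken into this assay, but the result for compound 3 is given only as "not determined" (no result reported), so compound 3 stands without a value of its own and can only be placed beside the numbers of compound 1 and compound 2. Compound 4, `ClCc1ccccc1Cn1cnc2ncnc(Cl)c21`, is the next compound and differs from compound 3 in one place: hydrogen in place of chloro on an aromatic carbon. With no number for compound 3, the size of the step to compound 4 in this assay cannot be measured; the author expects a step of modest size whose direction is open, and one that may well stay within the usual scatter. For compound 4 in this assay the author estimates 40000 nM, with a range from 5000 nM to 200000 nM.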

Compound 4, concentration lethal to 50% of the cells: 77600 nM
The estimate for compound 4 lay 1.9-fold (0.29 log units) below the measured number; measured number inside the range.
By their numbers in this assay, from the lowest: compound 1; then compounds 2 and 4 (each within the scatter of the next).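

No new step can be read here: compound 3 has no number in this assay to set against compound 4. The compounds shown leave open what hydrogen in place of chloro on the aromatic carbon does to the read-out. No measurement at hand offers an explanation for the number of compound 4.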